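Dipropylamino for azetidin-1-yl: notes on the series

The source may report more compounds than this note shows. Statements on the series, on what has been measured and on what is new or still open speak of the compounds shown alone.

In a functional assay on MGC-803 cells (Homo sapiens) for inhibition, read by sulforhodamine B assay (on this read-out lower numbers stand for stronger inhibition and higher numbers for weaker inhibition), compound 1 `O=C1C(Nc2ccc(I)cc2)=CC(=O)c2c1nc1n2[C@H]2OC[C@@H](O)[C@H]2OC1` gives 2150 nM and compound 2 `CCc1ccc(NC2=CC(=O)c3c(nc4n3[C@H]3OC[C@@H](O)[C@H]3OC4)C2=O)cc1` gives 1110 nM. Between these two the data show a 1.9-fold lower number from compound 1 to compound 2 (0.29 log units; within the scatter).

Compound 3 `O=C1C(N2CCC2)=CC(=O)c2c1nc1n2[C@H]2OC[C@@H](O)[C@H]2OC1` gives no number in this assay, only a limit of the assay at > 16000 nM.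

The next change, to compound 4 `CCCN(CCC)C1=CC(=O)c2c(nc3n2[C@H]2OC[C@@H](O)[C@H]2OC3)C1=O`, is dipropylamino in place of azetidin-1-yl on a double-bonded ring carbon. Among the measured compounds shown here, no measured step exchanges azetidin-1-yl for an open-chain amino group, and only the two steps that reach compound 3 bear on this one. Like compound 3, compound 4 has no (4-iodophenyl)amino or (4-ethylphenyl)amino group, and the loss of those groups gave an at least 7.4-fold higher number from compound 1 to compound 3 (0.87 log units; beyond the scatter) and an at least 14-fold higher number from compound 2 to compound 3 (1.15 log units; beyond the scatter). No return towards the numbers of compound 1 and compound 2 is expected, and a second reading at the limit is quite possible. The expected change is an at least 1.0-fold lower number from compound 3 to compound 4 (0.02 log units; that floor lies within the scatter), with no step beyond the scatter anticipated. For compound 4 the estimated value is 15000 nM, with an expected range of 5000 nM to 40000 nM.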

Compound 4, half-maximal inhibitory concentration: > 16000 nM
Compound 4: no number, only a limit; the forecaster's own chance of this, stated with the estimate: 55%; at least 1.0-fold (0.02 log units) between middle value and limit.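

In this assay, the open-chain dipropylamino group at this double-bonded ring carbon of the shared core behaves like the ring-closed azetidin-1-yl group, so the earlier reading is no longer confined to a single amine. Dipropylamino in place of the aryl amino groups gives an at least 14-fold higher number from compound 2 to compound 4 (1.15 log units; beyond the scatter) and an at least 7.4-fold higher number from compound 1 to compound 4 (0.87 log units; beyond the scatter), both beyond the scatter. The step between compound 3 and compound 4 cannot be read, because each compound reaches only the limit: the limit of > 16000 nM in this assay, at which 2 of the 4 values shown sit.

Among the compounds shown, measurable numbers remain confined to compound 1 and compound 2, both of which carry a substituted phenylamino group. From the compounds shown here alone, whether a propylamino group, a benzylamino group or an unsubstituted phenylamino group would give a number below the limit remains open.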